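Methoxyphenyl replaces methylthiazole on the ethenyl chain

The source may hold more compounds than are shown below. What is called first, only, known or untested is meant among the compounds shown, and "the series" means these compounds.

Compound 1 `COC(=O)/C=C/c1cccc(N(Cc2ccc(/C=C/c3scnc3C)cc2)C(=O)C2CCCCC2)c1`: 227 nM
Compound 2 `COC(=O)/C=C/c1cccc(N(Cc2cccc(Br)c2)C(=O)C2CCCCC2)c1`: > 1000 nM, a limit of the assay
Compound 3 `COC(=O)/C=C/c1cccc(N(Cc2ccc(/C=C/C(=O)OC(C)(C)C)cc2OCc2ccccc2)C(=O)C2CCCCC2)c1`: > 1000 nM, a limit of the assay

Of the compounds shown here, three share a core and have been tested in an assay on isolated protein with Bile acid receptor (Homo sapiens) as the target; on this read-out lower numbers stand for an effect already at smaller amounts and higher numbers for an effect only at larger amounts of compound. Among the compounds with values here, compound 1 is the only one with a number; the values of compound 2 and compound 3 sit at the limit of > 1000 nM in this assay, at which 2 of the 3 values shown sit. Compound 4 `COC(=O)/C=C/c1cccc(N(Cc2ccc(/C=C/c3ccc(OC)cc3)cc2)C(=O)C2CCCCC2)c1`, not yet measured, differs from compound 1 in one place: 4-methoxyphenyl in place of 4-methyl-1,3-thiazol-5-yl on a double-bonded chain carbon bound to a double-bonded chain carbon. Within the data shown here, no step between two measured compounds is available, so the expectation rests on compound 1 alone. A ring on the same chain carbon remains, and no step beyond the usual scatter is expected, a 1.3-fold higher number from compound 1 to compound 4 (0.12 log units; within the scatter). Compound 4 is estimated at 300 nM, within 100 nM to 1000 nM.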

Compound 4, half-maximal effective concentration: 208 nM
For compound 4 the middle estimate is 1.4-fold (0.16 log units) above the measured one; the range from low to high includes it.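

In this assay, 4-methoxyphenyl in place of 4-methyl-1,3-thiazol-5-yl gives a 1.1-fold lower number from compound 1 to compound 4 (0.04 log units; within the scatter). A six-membered aromatic ring of carbon only can therefore stand on this double-bonded chain carbon in place of a five-membered aromatic ring with 2 hetero atoms, with no step beyond the scatter. Nothing shown here gives a cause for this result.

As far as these compounds go, whether this chain carbon needs an aromatic ring at all remains open. An amine or a carboxylic acid in this place would test that.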